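The source may hold more compounds than are shown below. What is called first, only, known or untested is meant among the compounds shown, and "the series" means these compounds.

Working notes on the series. Compound 1 `O=C(Nc1sc2c(c1C(=O)NNc1ccccc1)CCCCC2)NS(=O)(=O)c1ccccc1` carries an anilino group on the hydrazide nitrogen; in a functional assay on OVCAR-3 cells (Homo sapiens) for inhibition, with a stated time of 48 h (a higher number here means a weaker inhibitor of growth, a lower number a stronger inhibitor of growth), compound 1 gives 15200 nM. Compound 2 `O=C(Nc1sc2c(c1C(=O)NNc1ccc(Cl)cc1)CCCCC2)NS(=O)(=O)c1ccccc1` adds a chloro group on an aromatic carbon. In this assay compound 2 reaches only the assay limit, > 100000 nM. Compound 3 `CCCNC(=O)c1c(NC(=O)NS(=O)(=O)c2ccccc2)sc2c1CCCCC2` carries propyl in place of anilino. In this assay compound 3 likewise reaches only the assay limit, > 100000 nM. The step of an at least 6.5-fold higher number from compound 1 to compound 3 (0.81 log units; beyond the scatter) thus ends at the limit, while a step that the two limits leave unreadable from compound 2 to compound 3. Compound 3 stands at the weak end of the measured set, known only through (the limit of > 100000 nM in this assay, at which 2 of the 3 values shown sit).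

Compound 4 `O=C(Nc1sc2c(c1C(=O)N1CCN(c3ccccc3)CC1)CCCCC2)NS(=O)(=O)c1ccccc1` differs from compound 3 by 4-phenylpiperazin-1-yl in place of propylamino on a carbonyl carbon. Only an at least 6.5-fold higher number from compound 1 to compound 3 (0.81 log units; beyond the scatter) bears on this change, and it points the other way: compound 1, with an aromatic ring on that nitrogen, gave 15200 nM. Compound 4 restores an aromatic ring, so a gain is expected, an at least 2.5-fold lower number from compound 3 to compound 4 (0.39 log units; beyond the scatter). Compound 4 is estimated at 40000 nM in this assay, between 8000 nM and 200000 nM.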

Compound 4, concentration for 50% growth inhibition: 11900 nM
Beside the measured number, compound 4's estimate is 3.4-fold (0.53 log units) above it; measured number inside the range.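

In this assay, 4-phenylpiperazin-1-yl on the carbonyl carbon gives an at least 8.4-fold lower number from compound 3 to compound 4 (0.92 log units; beyond the scatter), and likewise an at least 8.4-fold lower number from compound 2 to compound 4 (0.92 log units; beyond the scatter). Against anilinoamino the same change gives a 1.3-fold lower number from compound 1 to compound 4 (0.11 log units; within the scatter), so the hydrazide linkage is not required for this level of growth inhibition. The two weak members remain readable only as limits: the limit of > 100000 nM in this assay, at which 2 of the 4 values shown sit.

Open, as far as these compounds go, is whether the gain over propylamino follows the phenyl ring or the piperazine ring. A 4-methylpiperazin-1-yl group on the carbonyl carbon would bear on that.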